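Shortening the amine alkyl chain: solubility notes

This account rests on a few compounds, and the source may have more. Where it says the series, first, only, none or still open, it means among the compounds named here.

Compound 1, `O=[N+]([O-])c1cn2c(n1)OC[C@@H](NCc1ccc(OC(F)(F)F)cc1Oc1ccccc1)C2`: in a physicochemical assay for solubility, at pH 6.8 (a higher number here means a more soluble compound, a lower number a less soluble compound), compound 1 gives 3 ug/mL.
Compound 2, `CC(C)N(Cc1ccc(OC(F)(F)F)cc1)[C@@H]1COc2nc([N+](=O)[O-])cn2C1`: in this assay compound 2 gives < 2 ug/mL, which is a limit of the assay.
Compound 3, `CCCN(Cc1ccc(OC(F)(F)F)cc1)[C@@H]1COc2nc([N+](=O)[O-])cn2C1`: in this assay compound 3 gives < 2 ug/mL, which is a limit of the assay.

Compound 3 therefore stands at the floor of this assay, not at a number, and (the limit of < 2 ug/mL in this assay, at which 2 of the 3 values shown sit). For the measured compounds named here, the one measured step that touches it, a step that the two limits leave unreadable from compound 2 to compound 3, cannot be sized from two limits. Compound 4, `CN(Cc1ccc(OC(F)(F)F)cc1)[C@@H]1COc2nc([N+](=O)[O-])cn2C1`, differs from compound 3 as follows: hydrogen in place of ethyl on a saturated chain carbon bound to an amine nitrogen. Going by the values given here, no measured step bears on this change with a readable size, so the expected step of an at least 1.5-fold higher number from compound 3 to compound 4 (0.17 log units; that floor lies within the scatter) is an open guess around the floor. Compound 4 is expected to give 3 ug/mL, with a range of 1 ug/mL to 9 ug/mL.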

Compound 4, solubility: 10 ug/mL
Compound 4: the middle estimate sits 3.3-fold (0.52 log units) below what was measured, outside the stated range (above it).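

In this assay, for the compounds shown here, methyl on the amine nitrogen gives the first readable steps at this position: an at least 5.0-fold higher number from compound 3 to compound 4 (0.69 log units; beyond the scatter) with propyl leaving, and an at least 5.0-fold higher number from compound 2 to compound 4 (0.69 log units; beyond the scatter) with isopropyl leaving. Both sizes are lower bounds only, because compound 2 and compound 3 each sit at a limit: the limit of < 2 ug/mL in this assay, at which 2 of the 4 values shown sit. The step between those two cannot be read, so propyl and isopropyl remain unranked.

From the compounds shown here alone, whether an ethyl chain on the amine nitrogen gives a readable number or stays at the limit remains open. Going by these compounds, the effect of a hydroxyethyl chain there is also open.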